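The source may report more compounds than this note shows. Statements on the series, on what has been measured and on what is new or still open speak of the compounds shown alone.

Measured compounds in a functional assay on PC-3 cells (Homo sapiens) for inhibition, read by MTT assay, with a stated time of 48 h; a higher number here means a weaker inhibitor, a lower number a stronger inhibitor:
- compound 1 `COc1cc(N(Cc2nc3ccccc3[nH]2)S(=O)(=O)c2ccc(C)cc2)cc(OC)c1OC`: 3340 nM
- compound 2 `COc1cc(N(Cc2nc3ccccc3[nH]2)S(=O)(=O)c2ccccc2)cc(OC)c1OC`: 25500 nM
- compound 3 `COc1cc(N(Cc2nc3ccccc3[nH]2)S(=O)(=O)c2ccc(F)cc2)cc(OC)c1OC`: 7990 nM

Compound 3 stands second highest of the three numbers in this assay: its nearest neighbour is compound 1, with a 2.4-fold higher number from compound 1 to compound 3 (0.38 log units; beyond the scatter) on the way there, and its furthest is compound 2, with a 3.2-fold lower number from compound 2 to compound 3 (0.50 log units; beyond the scatter) on the way back. The unmeasured compound 4 `COc1cc(N(Cc2nc3ccccc3[nH]2)S(=O)(=O)c2ccc(Br)cc2)cc(OC)c1OC` is reached from compound 3 by one change: bromo in place of fluoro on an aromatic carbon.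

Among the compounds with values here, two measured steps bear on this change, both at the same aromatic carbon. From compound 2 to compound 3 the step was a 3.2-fold lower number from compound 2 to compound 3 (0.50 log units; beyond the scatter), and from compound 1 to compound 2 it was a 7.6-fold higher number from compound 1 to compound 2 (0.88 log units; beyond the scatter), so a fluoro and a methyl at this carbon both give lower numbers than hydrogen, methyl more so. Bromo is a one-heavy-atom group like fluoro and methyl, so compound 4 is expected to give a modestly lower number than compound 3, a step of a 2.3-fold lower number from compound 3 to compound 4 (0.36 log units; beyond the scatter). Compound 4 is therefore estimated at 3500 nM, with a range from 1200 nM to 10000 nM.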

Compound 4, half-maximal inhibitory concentration: 6890 nM
Compound 4: the middle estimate sits 2.0-fold (0.29 log units) below what was measured; low and high end bracket the measured number.
By their numbers in this assay, from the lowest: compound 1; then compounds 4 and 3 (each within the scatter of the next); then compound 2.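

In this assay, bromo and fluoro at this aromatic carbon cannot be told apart, since a 1.2-fold lower number from compound 3 to compound 4 (0.06 log units; within the scatter) is what separates them. Set against hydrogen, bromo gives the same direction of step that fluoro gave, with a 3.7-fold lower number from compound 2 to compound 4 (0.57 log units; beyond the scatter) as its size, while methyl keeps the lowest number of the four, as a 2.1-fold higher number from compound 1 to compound 4 (0.31 log units; beyond the scatter) shows for bromo in place of methyl. Nothing given here accounts for why methyl stands apart from the two halogens. The compounds shown leave open whether that low number belongs to methyl alone or extends to a longer chain such as ethyl. They also leave open what a methoxy group or an amine would give at this same carbon.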